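The compounds below may be only part of what the source reports. "The series", "measured", "known", "first", "only" and "open" are said of these compounds alone.

Two compounds share one core and differ only in the group on the triple-bonded carbon. Compound 1, `Nc1ccc(C#CC#Cc2cn([C@H]3C[C@H](O)[C@@H](CO)O3)c(=O)[nH]c2=O)cc1`, carries a 4-aminophenyl group; for compound 1 the result in an ADME assay on HEL cells (Homo sapiens), read by cell counting, with a stated time of 3 days (on this read-out lower numbers stand for higher toxicity in this test and higher numbers for lower toxicity in this test), is a limit, > 100000 nM, rather than a number. Compound 2, `CC(O)CC#CC#Cc1cn([C@H]2C[C@H](O)[C@@H](CO)O2)c(=O)[nH]c1=O`, carries a 2-hydroxypropyl group instead and in this assay gives 9500 nM. The step of an at least 10-fold lower number from compound 1 to compound 2 (1.02 log units; beyond the scatter) is large, and its starting point is a limit, (the limit of > 100000 nM in this assay, at which 1 of the 2 values shown sits). For the measured compounds named here, compound 2 thus holds the only real number among the values shown. Compound 3, `O=c1[nH]c(=O)n([C@H]2C[C@H](O)[C@@H](CO)O2)cc1C#CC#CCO`, is the next step: hydroxy in place of 1-hydroxyethyl on a saturated chain carbon bound to a triple-bonded carbon. Going by the values given here, no measured step shows this change, and the one measured step begins at a limit, so it offers no direct guide. The change keeps the hydroxy group and shortens the chain, and a step within the usual scatter is expected, a 1.6-fold higher number from compound 2 to compound 3 (0.20 log units; within the scatter). Compound 3 is therefore expected to give about 15000 nM in this assay, with a range from 5000 nM to 60000 nM.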

Compound 3, half-maximal cytotoxic concentration: > 100000 nM
Compound 3: only a limit was reported; the forecaster's own chance of this, stated with the estimate: 20%; middle value at least 6.6-fold (0.82 log units) away from the limit.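

Shortening 2-hydroxypropyl to hydroxymethyl keeps the hydroxy group, yet in this assay the change is far from neutral: the step is an at least 10-fold higher number from compound 2 to compound 3 (1.02 log units; beyond the scatter). For the compounds shown here, a hydroxy group on the chain therefore does not settle the result on its own, and the 4-aminophenyl group of compound 1 is not the only group here that gives a limit rather than a number. The step between compound 1 and compound 3 cannot be read, and neither compound can be placed above the other, because both results are limits: the limit of > 100000 nM in this assay, at which 2 of the 3 values shown sit.

Going by these compounds alone, compound 2 remains the only compound with a real number, so how far compound 3 truly lies from it stays unknown, and the printed step gives only its smallest possible size. The compounds shown also cannot separate chain length from branching, and a 2-hydroxyethyl group, a straight 3-hydroxypropyl group, or an amine in place of the hydroxy group on the 2-hydroxypropyl chain would be needed to tell which part of the change matters.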